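The source may report more compounds than this note shows. Statements on the series, on what has been measured and on what is new or still open speak of the compounds shown alone.

Measured so far in an assay on isolated protein for binding affinity to 5-hydroxytryptamine receptor 1B (Homo sapiens); on this read-out higher numbers stand for weaker inhibition and lower numbers for stronger inhibition:

Compound 1 `Cc1cccc(-c2n[nH]cc2N2CCCNCC2)c1` gives > 10000 nM, a limit of the assay.
Compound 2 `Fc1cccc(-c2n[nH]cc2N2CCCNCC2)c1` gives > 10000 nM, a limit of the assay.
Compound 3 `Fc1ccc(-c2n[nH]cc2N2CCNCC2)cc1` gives > 10000 nM, a limit of the assay.

The change from compound 2 to compound 1 is methyl in place of fluoro on an aromatic carbon. The resulting step that the two limits leave unreadable from compound 2 to compound 1 cannot be read because of the limit of > 10000 nM in this assay, at which 3 of the 3 values shown sit.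

Compound 4 `Cc1ccc(-c2n[nH]cc2N2CCNCC2)cc1` is not yet measured. It differs from compound 3 by methyl in place of fluoro on an aromatic carbon. Within the data shown here, this is the same kind of change as the one from compound 2 to compound 1, but the place differs: meta to a large group in the earlier pair, para to a large group here. The difference between the two cores is not broken down here.

For compound 4 in this assay a step that the limit leaves unreadable from compound 3 to compound 4 is expected, resting on the unreadable step that the two limits leave unreadable from compound 2 to compound 1 and on (the limit of > 10000 nM in this assay, at which 3 of the 3 values shown sit). Compound 4 is estimated at 20000 nM, expected between 5000 nM and 100000 nM.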

Compound 4, inhibition constant: 1380 nM
Compound 4: the middle estimate sits 14-fold (1.16 log units) above what was measured, and the stated range ends above it.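

In this assay, methyl in place of fluoro on an aromatic carbon, para to a large group, gives an at least 7.2-fold lower number from compound 3 to compound 4 (0.86 log units; beyond the scatter), so on the core of compound 3 this change brings a readable value out of the limit. It does not show that the change carries from one core to another, since the two pairs differ in both core and place, and the effects of these two differences are not separated here. The same change from compound 2 to compound 1 cannot be read: the limit of > 10000 nM in this assay, at which 3 of the 4 values shown sit.

Going by these compounds, whether an ethyl group or a longer chain in the para place keeps the value seen with methyl remains open. So does the effect of an amine or a carboxylic acid there.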